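The compounds below may be only part of what the source reports. "The series", "measured", "known", "first", "only" and "open" are said of these compounds alone.

Measured so far:
compound 1 `COc1cc(-c2nn(-c3cccc(NC(=O)Nc4cccc(C(F)(F)F)c4)c3)cc2-c2ccncc2)ccc1Cl` 3200 nM
compound 2 `COc1cc(-c2nn(-c3cccc(NC(=O)Nc4ccc(Cl)c(C(F)(F)F)c4)c3)cc2-c2ccncc2)ccc1Cl` 14900 nM

In a functional assay on SF-295 cells (Homo sapiens) for inhibition, read by sulforhodamine B assay, with a stated time of 48 h (on this read-out lower numbers stand for higher toxicity in this test and higher numbers for lower toxicity in this test), compound 2 stands highest of the two numbers, the change being a 4.7-fold higher number from compound 1 to compound 2 (0.67 log units; beyond the scatter). Compound 3 `COc1cc(-c2nn(-c3cccc(NC(=O)c4ccccc4)c3)cc2-c2ccncc2)ccc1Cl` differs from compound 2 by phenyl in place of (4-chloro-3-(trifluoromethyl)phenyl)amino on a carbonyl carbon. For the measured compounds named here, no measured step covers this change; the single step from compound 1 to compound 2 altered only the same outer ring and gives a loose pointer that this ring matters. The expected step is therefore uncertain and is set at a 1.9-fold lower number from compound 2 to compound 3 (0.27 log units; within the scatter). Compound 3 is estimated at 8000 nM, within a range of 2000 nM to 30000 nM.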

Compound 3, concentration lethal to 50% of the cells: > 100000 nM
Compound 3: no number, only a limit; the forecaster's own chance of this, stated with the estimate: 15%; at least 12-fold (1.09 log units) between middle value and limit.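

Compound 3 gives no number in this assay, only a limit: the limit of > 100000 nM in this assay, at which 1 of the 3 values shown sits.

Phenyl on the carbonyl carbon gives an at least 6.7-fold higher number from compound 2 to compound 3 (0.82 log units; beyond the scatter), and the same swap in the other urea gives an at least 31-fold higher number from compound 1 to compound 3 (1.49 log units; beyond the scatter). So the whole group on this carbonyl carbon matters to toxicity in this test, beyond the chloro on the outer ring, which gave a 4.7-fold higher number from compound 1 to compound 2 (0.67 log units; beyond the scatter).

The compounds shown leave open whether the amino nitrogen or the ring's chloro and trifluoromethyl groups carry this shift. A plain phenylamino group on the same carbonyl carbon would separate the two.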